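A few compounds are considered here, and "the series" means these few. Any claim that something is new, unique, unknown or untested is made for them only; others in the source may bear on it.

In a functional assay on PC-3 cells (Homo sapiens) for inhibition, read by colorimetric assay and MTT assay, with a stated time of 72 h (on this read-out higher numbers stand for weaker inhibition and lower numbers for stronger inhibition), the measured compounds stand as follows: compound 1 `C=CCCCCOc1ccccc1-c1cnc(OCCCC=C)n1C` gives 28000 nM; compound 2 `C=CCCCCCOc1ncc(-c2ccccc2OCCCCC=C)n1C` gives 70000 nM; compound 3 `C=CCCOc1ncc(-c2ccccc2OC)n1C` gives 25000 nM.

Compound 1 and compound 2 share a core and differ in one place, (but-3-en-1-yl in place of vinyl on a saturated chain carbon, three bonds along the chain from an oxygen on an aromatic ring). That change produced a 2.5-fold higher number from compound 1 to compound 2 (0.40 log units; beyond the scatter). Compound 3 carries a different core; how it differs from compound 1 is not broken down here, and the two values lie within the scatter of each other. Compound 4 `C=CCCCCOc1ncc(-c2ccccc2OC)n1C` has not yet been measured in this assay. It differs from compound 3 by but-3-en-1-yl in place of vinyl on a saturated chain carbon, two bonds along the chain from an oxygen on an aromatic ring. Among the measured compounds shown here, this is the same kind of change as the one between compound 1 and compound 2, but not the same: there the place was on a saturated chain carbon, three bonds along the chain from an oxygen on an aromatic ring, whereas here it is two bonds along the chain from an oxygen on an aromatic ring. Resting on a 2.5-fold higher number from compound 1 to compound 2 (0.40 log units; beyond the scatter), the expected step is a 2.0-fold higher number from compound 3 to compound 4 (0.30 log units; within the scatter), a modest weakening. Compound 4 is therefore estimated at 50000 nM in this assay, with a likely range from 20000 nM to 125000 nM.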

Compound 4, half-maximal inhibitory concentration: 24000 nM
For compound 4 the middle estimate is 2.1-fold (0.32 log units) above the measured one; the measured number falls inside the stated range.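

In this assay, replacing vinyl by but-3-en-1-yl on the core of compound 3 gave a 1.0-fold lower number from compound 3 to compound 4 (0.02 log units; within the scatter), so this change left no readable mark on that core. Set beside the earlier step, the two results cannot be told apart: the same change on two cores in this assay, a 2.5-fold higher number (0.40 log units; beyond the scatter) from compound 1 to compound 2 and a 1.0-fold lower number (0.02 log units; within the scatter) from compound 3 to compound 4, 2.6-fold (0.42 log units) apart, within the scatter of two such steps. Among the compounds shown here, this gives no firm sign that the effect of the change depends on the core, but it does not show that the effect carries over unaltered either: each core offers only a single step, and the place differs, three bonds along the chain from an oxygen on an aromatic ring in one case and two bonds in the other.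

The compounds shown leave open how a chain ending in an amine or a carboxylic acid, or a saturated chain without the terminal double bond, would read in this assay. They also leave open whether a hydroxy group in place of the methoxy group of compound 4 would alter the result.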